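The source may report more compounds than this note shows. Statements on the series, on what has been measured and on what is new or still open speak of the compounds shown alone.

The three measured compounds share one core and differ only in the chain on the amide-type nitrogen: compound 1 `CCCCNC(=O)CC1CCc2cc(OC)c(OC)cc21`, compound 2 `CCCCCNC(=O)CC1CCc2cc(OC)c(OC)cc21` and compound 3 `CCCCCCNC(=O)CC1CCc2cc(OC)c(OC)cc21`. In a functional assay on the whole organism (strain Wistar) for inhibition, with Rattus norvegicus as the target, read by paw edema, with stated times of 60 min and 4 h, at a dose of 100 mg/kg by the oral route (a higher number here means more inhibition at the dose given (going by the name of the read-out), a lower number less inhibition), compound 1 gives 25%, compound 2 gives 40.6%, and compound 3 gives 42.1%. On these numbers compound 3 stands at the top, though the step of a number 1.5 percentage points higher from compound 2 to compound 3 (within the scatter) is within the scatter, so compound 2 and compound 3 cannot be placed in order; only compound 1 lies clearly apart, as the steps of a number 15.6 percentage points higher from compound 1 to compound 2 (beyond the scatter) and a number 17.1 percentage points higher from compound 1 to compound 3 (beyond the scatter) show. Compound 4 `COc1cc2c(cc1OC)C(CC(=O)NCc1ccccc1)CC2` takes a different route: phenyl in place of pentyl on a saturated chain carbon bound to an amide-type nitrogen. For the measured compounds named here, no measured step exchanges a chain for a ring, so the only guide is the flat stretch between compound 2 and compound 3, where one more chain carbon changed nothing beyond the scatter. The step is therefore expected to be a number 2.1 percentage points lower from compound 3 to compound 4 (within the scatter), with no firm direction. Compound 4 is expected to give about 40%, within a range from 25% to 55%.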

Compound 4, a percentage reported as inhibition, in the whole organism at one dose (the size of the read-out at that dose, not a potency): 18.8%
Compound 4: the middle estimate sits 21.2 percentage points above what was measured; the whole stated range lies above it.
By their numbers in this assay, from the lowest: compounds 4 and 1 (each within the scatter of the next); then compounds 2 and 3 (each within the scatter of the next).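

In this assay, phenyl in place of pentyl on a saturated chain carbon bound to an amide-type nitrogen gives a number 23.3 percentage points lower from compound 3 to compound 4 (beyond the scatter) and phenyl in place of butyl gives a number 21.8 percentage points lower from compound 2 to compound 4 (beyond the scatter) at the same place. This position therefore responds to the kind of group it carries, which the chains alone did not show beyond the drop to the shortest chain. Phenyl in place of propyl gives a number 6.2 percentage points lower from compound 1 to compound 4 (within the scatter) so compound 4 cannot be placed in order with compound 1, and the ring keeps only the level of that chain.

From the compounds shown here alone, whether a cyclohexyl group would behave like the phenyl or like the chains stays open, as do a phenethyl group and a chain longer than hexyl. Nothing in the data speaks to why the phenyl lowers the number.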